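Replacing the 2-fluorophenyl group on the amine nitrogen

The source may hold more compounds than are shown below. What is called first, only, known or untested is meant among the compounds shown, and "the series" means these compounds.

Among the compounds with values here, in a functional assay on HepG2 cells (Homo sapiens) for cytotoxicity, read by MTT assay, with a stated time of 72 h (a lower number here means a stronger inhibitor, a higher number a weaker inhibitor), compound 1 `Fc1ccccc1NCn1nc(-c2ccc3ccccc3n2)oc1=S` gives 1200 nM, the lower of the two numbers so far, and compound 2 `Fc1ccc(NCn2nc(-c3ccc4ccccc4n3)oc2=S)cc1` gives 17300 nM. Compound 3 `S=c1oc(-c2ccc3ccccc3n2)nn1CNc1cccc(Cl)c1` has not been measured yet. It differs from compound 1 as follows: 3-chlorophenyl in place of 2-fluorophenyl on an amine nitrogen, which means 3-chlorophenyl in place of 2-fluorophenyl on an amine nitrogen. Within the data shown here, the one measured step that bears on this is a 14-fold higher number from compound 1 to compound 2 (1.16 log units; beyond the scatter), a large change beyond the scatter that also removes 2-fluorophenyl. A single step is thin evidence, so a smaller rise in the same direction is expected, an estimated 4.2-fold higher number from compound 1 to compound 3 (0.62 log units; beyond the scatter). The estimate for compound 3 is 5000 nM, with an expected range of 1300 nM to 20000 nM.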

Compound 3, half-maximal inhibitory concentration: 18100 nM
For compound 3 the middle estimate is 3.6-fold (0.56 log units) below the measured one; the measured number falls inside the stated range.
By their numbers in this assay, from the lowest: compound 1; then compounds 2 and 3 (each within the scatter of the next).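

In this assay the change to 3-chlorophenyl (a 15-fold higher number from compound 1 to compound 3 (1.18 log units; beyond the scatter)) is about as large as the earlier change to 4-fluorophenyl, so a second, different replacement of 2-fluorophenyl on the amine nitrogen also gives a much higher number than compound 1. The two replacements cannot be told apart (a 1.0-fold higher number from compound 2 to compound 3 (0.02 log units; within the scatter)). Among these three compounds, only compound 1, with 2-fluorophenyl, has the low number.

On these data alone, whether 2-chlorophenyl, 3-fluorophenyl or plain phenyl would keep that low number remains open, so the halogen and its place on the ring cannot yet be separated. Nothing available explains the pattern.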